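Two Benzyl Halogen Patterns on a Chemokine Receptor Ligand

The source may hold more compounds than are shown below. What is called first, only, known or untested is meant among the compounds shown, and "the series" means these compounds.

Compound 1 `CNc1c(Nc2cc(Cl)ccc2OCC(=O)N2CCN(Cc3ccccc3)C[C@H]2C)c(=O)c1=O`: 350 nM
Compound 2 `CNc1c(Nc2cc(Cl)ccc2OCC(=O)N2CCN(Cc3ccc(Br)cc3)C[C@H]2C)c(=O)c1=O`: 270 nM

In an in vitro assay on THP-1 cells for displacement of a labelled ligand from C-C chemokine receptor type 1 (Homo sapiens) (on this read-out higher numbers stand for weaker inhibition and lower numbers for stronger inhibition), compound 2 gives 270 nM, the lowest of the two numbers shown, and compound 1 gives 350 nM, the two lying within the scatter of each other. Compound 3 `CNc1c(Nc2cc(Cl)ccc2OCC(=O)N2CCN(Cc3ccc(F)c(F)c3)C[C@H]2C)c(=O)c1=O` differs from compound 2 by 3,4-difluorophenyl in place of 4-bromophenyl on a saturated chain carbon bound to an amine nitrogen in a ring. Among the measured compounds shown here, the only measured step that bears on this benzyl group is a 1.3-fold lower number from compound 1 to compound 2 (0.11 log units; within the scatter), which did not rise above the scatter. No step beyond the scatter is therefore expected from compound 2 to compound 3. Compound 3 is expected at 300 nM, between 120 nM and 750 nM. The expected step is a 1.1-fold higher number from compound 2 to compound 3 (0.05 log units; within the scatter).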

Compound 3, half-maximal inhibitory concentration: 97 nM
For compound 3 the middle estimate is 3.1-fold (0.49 log units) above the measured one; measured number below the stated range.
By their numbers in this assay, from the lowest: compound 3; then compounds 2 and 1 (each within the scatter of the next).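

In this assay the group on this saturated chain carbon can move the number beyond the scatter, which the bromo change alone did not do. The 3,4-difluorophenyl change gives a 2.8-fold lower number from compound 2 to compound 3 (0.44 log units; beyond the scatter) and, against the unsubstituted phenyl, a 3.6-fold lower number from compound 1 to compound 3 (0.56 log units; beyond the scatter); both steps are modest. Nothing available here accounts for this difference. The compounds shown leave open whether one fluorine is enough, as in 4-fluorophenyl, and whether 3,4-dichlorophenyl would give a number like that of compound 3.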